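The source may hold more compounds than are shown below. What is called first, only, known or untested is meant among the compounds shown, and "the series" means these compounds.

Compound 1 `CCC(C(=O)NCc1ccc(C(F)(F)F)nc1N1CCC(C)CC1)c1ccc(NS(C)(=O)=O)c(F)c1`: in an assay on CHO cells for antagonist activity at transient receptor potential cation channel subfamily V member 1 (Homo sapiens), read by FLIPR (on this read-out higher numbers stand for weaker inhibition and lower numbers for stronger inhibition), compound 1 gives 1.6 nM
Compound 2 `CC1CCN(c2nc(C(F)(F)F)ccc2CNC(=O)C(Cc2ccccc2)c2ccc(NS(C)(=O)=O)c(F)c2)CC1`: in this assay compound 2 gives 65.9 nM

Of these two numbers, compound 2 has the higher one, set apart from compound 1 by a 41-fold higher number from compound 1 to compound 2 (1.61 log units; beyond the scatter). Compound 3 `CC1CCN(c2nc(C(F)(F)F)ccc2CNC(=O)C(Cc2ccc(F)cc2)c2ccc(NS(C)(=O)=O)c(F)c2)CC1` differs from compound 2 by fluoro in place of hydrogen on an aromatic carbon. For the measured compounds named here, the one measured step concerns swapping in the whole phenyl group, not a single fluorine on it, so it offers little direct guidance. With nothing closer to go on, the expected change in this assay is one that stays within the scatter, estimated as a 1.1-fold lower number from compound 2 to compound 3 (0.04 log units; within the scatter). Compound 3 is therefore expected to give about 60 nM, between 25 nM and 150 nM.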

Compound 3, inhibition constant: 49.3 nM
Compound 3: the middle estimate sits 1.2-fold (0.09 log units) above what was measured, within the range that was stated.
By their numbers in this assay, from the lowest: compound 1; then compounds 3 and 2 (each within the scatter of the next).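

In this assay, going from phenyl to 4-fluorophenyl at this position brings a 1.3-fold lower number from compound 2 to compound 3 (0.13 log units; within the scatter), so this fluoro on the ring does not measurably change the result. The large gap opened by the phenyl group remains with 4-fluorophenyl in place of methyl, as shown by a 31-fold higher number from compound 1 to compound 3 (1.49 log units; beyond the scatter). No measurement here explains either step. Still open, going by these compounds, is whether a chloro or methoxy group at that ring position would also stay within the scatter. Also open, on these data alone, is whether an ethyl or propyl group in place of the methyl would keep the low number of compound 1.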